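The compounds below may be only part of what the source reports. "The series", "measured", "known", "first", "only" and "open" are said of these compounds alone.

Of the compounds shown here, two have been measured. Compound 1 `CC1(C)C(=O)N(c2ccccc2Cl)c2ncccc21` gives 3% in a functional assay on the whole organism (Pleural cavity) for inhibition, with Rattus norvegicus as the target, at a dose of 25 mg/kg; on this read-out lower numbers stand for less inhibition and higher numbers for more inhibition at the one dose given (going by the name of the read-out). Compound 2 `COc1ccc(N2C(=O)C(C)(C)c3cccnc32)cc1` gives 42% in this assay, the higher of the two numbers, with compound 1 the nearest and beyond the usual scatter below it. Compound 3 `C[S+]([O-])c1ccc(N2C(=O)C(C)(C)c3cccnc32)cc1` has not been measured; it differs from compound 2 as follows: a group of 3 heavy atoms (1 carbon, 1 oxygen, 1 sulfur; no ring) in place of a group of 2 heavy atoms (1 carbon, 1 oxygen; no ring), on an aromatic carbon. Within the data shown here, with no measured step of this kind to lean on, the step is expected to be none beyond the scatter: a number 2 percentage points lower from compound 2 to compound 3 (within the scatter). Compound 3 is therefore estimated to give 40% in this assay, between 15% and 65%.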

Compound 3, a percentage reported as inhibition, in the whole organism at one dose (the size of the read-out at that dose, not a potency): 0%
For compound 3 the middle estimate is 40 percentage points above the measured one; measured number below the stated range.
By their numbers in this assay, from the lowest: compounds 3 and 1 (each within the scatter of the next); then compound 2.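

In this assay, the site on the aromatic carbon para to a large group proves sensitive to what it carries: replacing methoxy with the sulfur-bearing group gives a number 42 percentage points lower from compound 2 to compound 3 (beyond the scatter). The two groups have the same hydrogen-bond donor and acceptor counts and neither has a net charge, so these counts do not separate them. Nothing measured here accounts for the drop.

The compounds shown leave open whether an amine, a carboxylic acid or a longer alkoxy chain at this site would behave like methoxy. They also leave open whether a methylthio group would.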